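Swapping Ethoxy for Bromo on the Anilino Ring

The source may report more compounds than this note shows. Statements on the series, on what has been measured and on what is new or still open speak of the compounds shown alone.

Measured so far, in a functional assay on SAOS-2 cells (Homo sapiens) for antiproliferative activity, read by MTT assay, with a stated time of 72 h; a higher number here means a weaker inhibitor, a lower number a stronger inhibitor:
compound 1, `CCCCOC1=C(C(=O)c2ccccc2)C(c2ccc(Br)cc2)N(CCCn2ccnc2)C1=O`, gives 11600 nM;
compound 2, `O=C(C1=C(Nc2ccccc2)C(=O)N(CCCn2ccnc2)C1c1ccc(Br)cc1)c1ccccc1`, gives 24400 nM;
compound 3, `CCOc1ccc(NC2=C(C(=O)c3ccccc3)C(c3ccc(Br)cc3)N(CCCn3ccnc3)C2=O)cc1`, gives 30900 nM.

Compound 3 holds the highest of these three numbers. Its nearest neighbour is compound 2, and that step, a 1.3-fold higher number from compound 2 to compound 3 (0.10 log units; within the scatter), lies within the scatter, so the two cannot be ordered. The step of a 2.7-fold higher number from compound 1 to compound 3 (0.43 log units; beyond the scatter) is modest but beyond the scatter.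

Compound 4, `O=C(C1=C(Nc2ccc(Br)cc2)C(=O)N(CCCn2ccnc2)C1c1ccc(Br)cc1)c1ccccc1`, differs from compound 3 in one place: bromo in place of ethoxy on an aromatic carbon. Among the compounds with values here, only one measured step touches this ring, a 1.3-fold higher number from compound 2 to compound 3 (0.10 log units; within the scatter), and it stayed within the scatter. Within the data shown here, no measured step involves a bromo at that position. The expected step is therefore small, a 1.1-fold lower number from compound 3 to compound 4 (0.04 log units; within the scatter). Compound 4 is estimated at 28000 nM. The expected range for compound 4 runs from 12000 nM to 65000 nM.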

Compound 4, half-maximal inhibitory concentration: 23800 nM
The estimate for compound 4 lay 1.2-fold (0.07 log units) above the measured number; measured number inside the range.
By their numbers in this assay, from the lowest: compound 1; then compounds 4, 2 and 3 (each within the scatter of the next).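

In this assay, this ring position now carries hydrogen, ethoxy or bromo with no step beyond the scatter, whether ethoxy gives way to bromo (a 1.3-fold lower number from compound 3 to compound 4 (0.11 log units; within the scatter)) or bromo replaces hydrogen (a 1.0-fold lower number from compound 2 to compound 4 (0.01 log units; within the scatter)). The gap to the butoxy compound remains modest but beyond the scatter with bromo in place (a 2.1-fold higher number from compound 1 to compound 4 (0.31 log units; beyond the scatter)). Nothing measured here explains why these ring groups read alike. From the compounds shown here alone, whether an amine or a carboxylic acid at this position would give a step beyond the scatter stays open.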